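Swapping Nitro for Amino in Compound 2

The source may report more compounds than this note shows. Statements on the series, on what has been measured and on what is new or still open speak of the compounds shown alone.

In a functional assay on DU-145 cells (Homo sapiens) for cytotoxicity, read by trypan blue exclusion, with a stated time of 96 h (on this read-out lower numbers stand for stronger inhibition and higher numbers for weaker inhibition), compound 1 (`COc1ccc(CS(=O)(=O)/C=C/c2c(OC)cccc2OC)cc1[N+](=O)[O-]`) gives 20000 nM and compound 2 (`COc1ccc(CS(=O)(=O)/C=C/c2c(OC)cccc2OC)c([N+](=O)[O-])c1`) gives 50000 nM as the higher of the two numbers, a gap beyond the usual scatter. Compound 3 (`COc1ccc(CS(=O)(=O)/C=C/c2c(OC)cccc2OC)c(N)c1`) carries amino in place of nitro on an aromatic carbon of compound 2 (amino in place of nitro on an aromatic carbon). Among the compounds with values here, no measured pair shows this swap, so what follows is a judgement with a wide margin. A clear drop in the number is expected, with a 10-fold lower number from compound 2 to compound 3 (1.00 log units; beyond the scatter) as the estimated step toward stronger inhibition. Compound 3 is estimated at 5000 nM with 300 nM to 40000 nM as its expected range.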

Compound 3, half-maximal inhibitory concentration: 750 nM
Estimate against measurement, compound 3: 6.7-fold (0.82 log units) above; low and high end bracket the measured number.
By their numbers in this assay, from the lowest: compound 3; then compound 1; then compound 2.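

Swapping nitro for amino on this aromatic carbon, ortho to a large group, gives a 67-fold lower number from compound 2 to compound 3 (1.82 log units; beyond the scatter) in this assay from this single change. Nitro was the only group seen here before, so this is the first sign that the group at this position can strongly shift the number. Nothing available explains the size of this step.

The compounds shown leave open whether an acetamide or a methylamino group on this carbon would act like amino, and whether amino in place of the nitro of compound 1 would give a similar step.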